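Shortening the Side Chain of Compound 3 to a Hydroxyl

The compounds below may be only part of what the source reports. "The series", "measured", "known", "first", "only" and "open" are said of these compounds alone.

Three compounds share one core and differ only in the group on a saturated chain carbon bound to a double-bonded nitrogen. In an assay on isolated protein for inhibition of myosin-2 (Bos taurus), read by spectrophotometry, with a stated time of 24 min (on this read-out higher numbers stand for weaker inhibition and lower numbers for stronger inhibition), compound 1 `C/C(=N\Cc1ccccn1)c1c(O)c2ccccc2oc1=O` gives 22000 nM. Compound 2 `C/C(=N\CCCO)c1c(O)c2ccccc2oc1=O` gives 37000 nM and compound 3 `C/C(=N\CC(C)C)c1c(O)c2ccccc2oc1=O` gives 34000 nM in this assay. The steps are a 1.7-fold higher number from compound 1 to compound 2 (0.23 log units; within the scatter) and a 1.5-fold higher number from compound 1 to compound 3 (0.19 log units; within the scatter), and between the two chains without a ring, a 1.1-fold lower number from compound 2 to compound 3 (0.04 log units; within the scatter). Compound 3 thus sits second highest of the three numbers, its nearest neighbour compound 2 and its furthest compound 1, all within the scatter.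

Compound 4 `C/C(=N\CCO)c1c(O)c2ccccc2oc1=O` takes the next step from compound 3: hydroxymethyl in place of isopropyl on a saturated chain carbon bound to a double-bonded nitrogen. The step most like it is the swap of 2-hydroxyethyl for isopropyl between compound 2 and compound 3, which moved the number hardly at all; the other two steps were also within the scatter. No step beyond the scatter is therefore expected in this assay, so a 1.0-fold lower number from compound 3 to compound 4 (0.01 log units; within the scatter) is the expected change. Compound 4 is expected to give 33000 nM, estimated between 15000 nM and 75000 nM.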

Compound 4, half-maximal inhibitory concentration: 92000 nM
Beside the measured number, compound 4's estimate is 2.8-fold (0.45 log units) below it; the whole stated range lies below it.
By their numbers in this assay, from the lowest: compounds 1, 3 and 2 (each within the scatter of the next); then compound 4.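

Going by these compounds alone, this position is not as indifferent as the first three compounds suggested: in this assay, compound 4 is the first to move beyond the scatter, with a 2.7-fold higher number from compound 3 to compound 4 (0.43 log units; beyond the scatter) and a 4.2-fold higher number from compound 1 to compound 4 (0.62 log units; beyond the scatter). A hydroxyl on the chain does not by itself set compound 4 apart, as compound 2 also carries one and stays within the scatter of compound 1 and compound 3. Shortening that hydroxyl-bearing chain, however, gives a 2.5-fold higher number from compound 2 to compound 4 (0.40 log units; beyond the scatter), so the length of the chain matters here. Nothing at hand shows why the shorter chain gives weaker inhibition.

On these data alone, it remains open whether this loss follows from the short chain alone or from the hydroxyl at that short length. An ethyl group or a 2-aminoethyl chain in the same place would help separate the two.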